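This account rests on a few compounds, and the source may have more. Where it says the series, first, only, none or still open, it means among the compounds named here.

Measured in a functional assay; a lower number here means a stronger inhibitor, a higher number a weaker inhibitor:
- compound 1 `CC(C)=CCOc1ccc2c(c1)OC(c1cccc(Br)c1)CC2=O`: 5280 nM
- compound 2 `CC(C)=CCOc1ccc2c(c1)OC(c1ccc(C)cc1)CC2=O`: 4440 nM
- compound 3 `COc1ccc(C2CC(=O)c3ccc(OCC=C(C)C)cc3O2)cc1`: 10200 nM

These three compounds share a core and differ only in the aromatic group on a saturated ring carbon. Compound 3 cannot be told apart from compound 1, with a 1.9-fold higher number from compound 1 to compound 3 (0.29 log units; within the scatter). It does separate from compound 2, with a 2.3-fold higher number from compound 2 to compound 3 (0.36 log units; beyond the scatter), though only modestly.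

The next compound is compound 4 `CC(C)=CCOc1ccc2c(c1)OC(c1ccc(C)cc1C)CC2=O`, which has 2,4-dimethylphenyl in place of 4-methoxyphenyl on a saturated ring carbon, next to the ring oxygen (2,4-dimethylphenyl in place of 4-methoxyphenyl on a saturated ring carbon). The closest guide is the methoxy-for-methyl step, a 2.3-fold higher number from compound 2 to compound 3 (0.36 log units; beyond the scatter). Read backwards, it suggests that losing the methoxy should lower the number by a modest amount. The step of a 1.2-fold lower number from compound 1 to compound 2 (0.08 log units; within the scatter) shows that a different group on this carbon can leave the number within the scatter. Among the compounds with values here, the second methyl group of compound 4 has no measured counterpart, so its contribution is unknown. A modest drop is therefore expected, and it may not clear the scatter. The step expected is a 2.0-fold lower number from compound 3 to compound 4 (0.31 log units; beyond the scatter). For compound 4 the estimated value is 5000 nM. The expected range for compound 4 runs from 2200 nM to 10500 nM.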

Compound 4, half-maximal inhibitory concentration: 8260 nM
Compound 4: middle estimate off by 1.7-fold (0.22 log units), on the low side; measured number inside the range.
By their numbers in this assay, from the lowest: compounds 2, 1, 4 and 3 (each within the scatter of the next, the first and the last beyond it).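

In this assay, replacing 4-methoxyphenyl with 2,4-dimethylphenyl on this saturated ring carbon gives no change that can be told from the scatter (a 1.2-fold lower number from compound 3 to compound 4 (0.09 log units; within the scatter)), even though the group entering has no hydrogen-bond acceptor and the group leaving has one. Adding a methyl in place of hydrogen on the aromatic ring of compound 2 also stays within the scatter (a 1.9-fold higher number from compound 2 to compound 4 (0.27 log units; within the scatter)), as does the exchange of 3-bromophenyl for 2,4-dimethylphenyl (a 1.6-fold higher number from compound 1 to compound 4 (0.19 log units; within the scatter)). Within the data shown here, compound 4 therefore cannot be separated from any of the other three compounds, so this second methyl adds no measurable effect, and the modest gap between compound 2 and compound 3 remains the only step here beyond the scatter.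

No independent measurement is available to explain these numbers. From the compounds shown here alone, it remains open whether an aromatic ring carrying an amine or a carboxylic acid, or a longer chain on this carbon in place of the ring, would shift the number in this assay clearly beyond the scatter.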